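Aryl Exchange on a Shared Core: Cytotoxicity Outlook

The compounds below may be only part of what the source reports. "The series", "measured", "known", "first", "only" and "open" are said of these compounds alone.

Measured so far in an ADME assay on L929 cells (Mus musculus) for cytotoxicity, read by resazurin assay, with a stated time of 72 h; on this read-out higher numbers stand for weaker inhibition and lower numbers for stronger inhibition:
compound 1, `O=C(/C=C/c1ccc2c(c1)B(O)OC2)c1ccc(I)cc1`: > 10 ug/mL
compound 2, `COc1cccc(C(=O)CCc2ccc3c(c2)B(O)OC3)c1`: > 10 ug/mL

The value for compound 1 is a limit of this assay rather than a number. The value for compound 2 is likewise a limit. Compound 1 therefore stands at the limit of > 10 ug/mL in this assay, at which 2 of the 2 values shown sit, and nothing in the two measurements separates it from compound 2.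

Compound 3, `Nc1cccc(C(=O)/C=C/c2ccc3c(c2)B(O)OC3)c1`, has not yet been tested. It differs from compound 1 by 3-aminophenyl in place of 4-iodophenyl on a carbonyl carbon. Among the compounds with values here, no pair of measured compounds that differ in one place is available, so the size of this step can only be anticipated: in this assay the expected step that the limit leaves unreadable from compound 1 to compound 3 is small, none beyond the usual scatter. Given (the limit of > 10 ug/mL in this assay, at which 2 of the 2 values shown sit), compound 3 is estimated at 15 ug/mL, with a range from 7 ug/mL to 40 ug/mL, and most likely the assay will again report only a limit.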

Compound 3, half-maximal inhibitory concentration: 10 ug/mL
Beside the measured number, compound 3's estimate is 1.5-fold (0.18 log units) above it; measured number inside the range.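

In this assay, 3-aminophenyl in place of 4-iodophenyl on a carbonyl carbon gives a number no higher from compound 1 to compound 3 (the limit leaves the size open). Within the data shown here, compound 3 is the only one of the three compounds to give a number rather than a limit: compound 3 gives 10 ug/mL. The value of compound 1, > 10 ug/mL, is a limit, so the size of this step cannot be read: the limit of > 10 ug/mL in this assay, at which 2 of the 3 values shown sit. The change therefore shows that a group at this place can bring the read-out to a number, but not how far compound 3 lies from compound 1.

The compounds shown leave open how a plain phenyl, a 4-aminophenyl or a phenyl carrying a carboxylic acid would read on this carbonyl carbon. They also leave open how 3-aminophenyl would read on the chain of compound 2.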